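Benzyl for Methyl on a Phthalimide-Bearing Triazole Pair

The source may report more compounds than this note shows. Statements on the series, on what has been measured and on what is new or still open speak of the compounds shown alone.

Compound 1 `CCCc1nnc(SCc2ccccc2)n1N1C(=O)c2ccccc2C1=O` and compound 2 `CCCc1nnc(SC)n1N1C(=O)c2ccccc2C1=O` share one core and differ by phenyl in place of hydrogen on a saturated chain carbon bound to a sulfur. In a functional assay on HepG2 cells (Homo sapiens) for cytotoxicity, read by MTT assay, with a stated time of 48 h (on this read-out lower numbers stand for stronger inhibition and higher numbers for weaker inhibition), compound 1 gives > 200000 nM, which is a limit of the assay and not a number. Compound 2 gives > 200000 nM, likewise a limit. The step that the two limits leave unreadable from compound 2 to compound 1 is therefore unreadable. Compound 3 `COc1cc(-c2nnc(SC)n2N2C(=O)c3ccccc3C2=O)cc(OC)c1OC` carries a different core; how its core differs from that of compound 2 is not broken down here. Compound 3 gives > 200000 nM, again a limit. Compound 4 `COc1cc(-c2nnc(SCc3ccccc3)n2N2C(=O)c3ccccc3C2=O)cc(OC)c1OC` stands to compound 3 as compound 1 stands to compound 2, by phenyl in place of hydrogen on a saturated chain carbon bound to a sulfur. Within the data shown here, because every measured value sits at the limit of > 200000 nM in this assay, at which 3 of the 3 values shown sit, no measured step speaks for or against this change. Compound 4 is accordingly expected to give about 250000 nM, with a plausible range from 100000 nM to 600000 nM. The step that the limit leaves unreadable from compound 3 to compound 4 that this estimate means is expected to be close to nil, and another limit is the most likely report.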

Compound 4, half-maximal inhibitory concentration: > 200000 nM
Compound 4: a limit, no number; the forecaster's own chance of this, stated with the estimate: 85%; the middle value does not contradict the limit.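

In this assay compound 4 gives > 200000 nM which is a limit and not a number. No new step can be read from compound 3 or compound 1 to compound 4: the limit of > 200000 nM in this assay, at which 4 of the 4 values shown sit. The compounds shown leave open whether either change alters cytotoxicity at all.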